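The source may report more compounds than this note shows. Statements on the series, on what has been measured and on what is new or still open speak of the compounds shown alone.

Working notes on the series. Two compounds carry numbers in an assay on CHO cells for displacement of a labelled ligand from adenosine receptor A3 (Homo sapiens); a lower number here means a stronger inhibitor, a higher number a weaker inhibitor. Compound 1 `Nc1ncnc2c1nc(-c1ccco1)n2CCCO` gives 4300 nM there, and compound 2 `Cc1ccc(NC(=O)Nc2ncnc3c2nc(-c2ccco2)n3C)cc1` gives 38000 nM in this assay. Compound 2 thus has the higher of the two numbers, and its gap to compound 1 lies beyond the scatter. The step considered runs from compound 2 to the unmeasured compound 3 `Cn1c(-c2ccco2)nc2c(NC(=O)Nc3ccccc3)ncnc21`. The change is hydrogen in place of methyl on an aromatic carbon, so that 4-methylphenyl becomes phenyl and (4-methylphenyl)amino becomes anilino. Among the compounds with values here, no step of this kind occurs between the two measured compounds, so neither direction is supported by a measured pair. The loss of the methyl is expected to move the number little, a step of a 1.3-fold lower number from compound 2 to compound 3 (0.10 log units; within the scatter) that stays within the scatter. Compound 3 is therefore estimated at 30000 nM in this assay, with a range from 10000 nM to 100000 nM.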

Compound 3, inhibition constant: 23300 nM
Compound 3: middle estimate off by 1.3-fold (0.11 log units), on the high side; the range from low to high includes it.
By their numbers in this assay, from the lowest: compound 1; then compounds 3 and 2 (each within the scatter of the next).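

Hydrogen in place of methyl on an aromatic carbon, para to a large group, gives a 1.6-fold lower number from compound 2 to compound 3 (0.21 log units; within the scatter) in this assay, and this is the only measured pair of its kind in the series. At this position, then, the methyl can be lost without the number leaving the scatter, so compound 2 and compound 3 cannot be told apart in this assay. Nothing measured on these compounds speaks to the reason for this outcome.

Open, on these data alone, is whether a larger or different group at this place, such as methoxy, chlorine or a carboxylic acid, would move the number beyond the scatter in this assay. Also open, as far as these compounds go, is whether the same change reads alike when the methyl on the core of compound 3 gives way to a longer chain carrying a hydroxyl group.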